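Trimming the amide chain from compound 3 to compound 4

The source may hold more compounds than are shown below. What is called first, only, known or untested is meant among the compounds shown, and "the series" means these compounds.

In a functional assay (MOLM-13 cells, Homo sapiens) for inhibition, with Mus musculus as the target, read by resazurin assay, with a stated time of 72 h (on this read-out lower numbers stand for stronger inhibition of growth and higher numbers for weaker inhibition of growth), compound 1 `Cc1c(C(=O)O)sc2ncnc(Nc3ccc(F)cc3)c12` gives 79300 nM, compound 2 `Cc1c(C(N)=O)sc2ncnc(Nc3ccc(F)cc3OC(C)C)c12` gives 6120 nM and compound 3 `COCCCNC(=O)c1sc2ncnc(Nc3ccc(F)cc3OC(C)C)c2c1C` gives 50400 nM. The values of compound 1 and compound 3 lie within the scatter of each other, so the two cannot be ranked. Going by the values given here, the single measured step is an 8.2-fold higher number from compound 2 to compound 3 (0.92 log units; beyond the scatter), and it adds 3-methoxypropyl in place of hydrogen on an amide-type nitrogen.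

Compound 4 `CNC(=O)c1sc2ncnc(Nc3ccc(F)cc3OC(C)C)c2c1C` has hydrogen in place of 2-methoxyethyl on a saturated chain carbon bound to an amide-type nitrogen. The group on that nitrogen thus goes from 3-methoxypropyl to methyl. One step is thin evidence, but a partial return along an 8.2-fold higher number from compound 2 to compound 3 (0.92 log units; beyond the scatter) is expected in this assay, toward a lower number and not all the way back. The expected change is a 3.4-fold lower number from compound 3 to compound 4 (0.53 log units; beyond the scatter). The estimate for compound 4 is 15000 nM, with an expected range of 5500 nM to 42000 nM.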

Compound 4, concentration for 50% growth inhibition: 5760 nM
For compound 4 the middle estimate is 2.6-fold (0.42 log units) above the measured one; measured number inside the range.
By their numbers in this assay, from the lowest: compounds 4 and 2 (each within the scatter of the next); then compounds 3 and 1 (each within the scatter of the next).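

In this assay, cutting the group on the amide-type nitrogen from 3-methoxypropyl to methyl gives an 8.8-fold lower number from compound 3 to compound 4 (0.94 log units; beyond the scatter), so the rise in the number seen with the longer chain does not persist once the 2-methoxyethyl part is removed. The methyl group itself leaves no readable mark, with a 1.1-fold lower number from compound 2 to compound 4 (0.03 log units; within the scatter), which means that among these compounds the higher number goes with 3-methoxypropyl and not with substitution on that nitrogen as such. Nothing measured here bears on why the number follows this group.

Going by these compounds, whether chain length or the ether oxygen carries the step remains open, and an ethyl group or an unbranched propyl chain on that nitrogen would separate the two. On these data alone, how a terminal amine or carboxylic acid on the chain would read is equally open.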